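From dichlorophenyl to bromo-methoxyphenyl: estimating a half-life

The source may hold more compounds than are shown below. What is called first, only, known or untested is meant among the compounds shown, and "the series" means these compounds.

Measured in an ADME assay on microsomes from liver (Rattus norvegicus) for metabolic stability, read by LC-MS, using NADPH, at 37 degrees C; a higher number here means that the compound lasts longer, a lower number that the compound disappears faster:
- compound 1 `Cc1oc(-c2ccc(Cl)cc2)nc1CN1CCC(C(=O)NCCCN2C[C@H](C)C[C@H](C)C2)CC1`: > 0.5 h (a limit of the assay, not a number)
- compound 2 `Cc1ccccc1-c1nc(CN2CCC(C(=O)NCCCN3CCCCC3)CC2)c(C)o1`: > 0.5 h (a limit of the assay, not a number)
- compound 3 `Cc1oc(-c2c(Cl)cccc2Cl)nc1CN1CCC(C(=O)NCCCN2C[C@H](C)C[C@H](C)C2)CC1`: 0.0483 h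

Among the compounds with values here, compound 3 gives 0.0483 h, the only true number in this small set. The other two compounds sit at the limit of > 0.5 h in this assay, at which 2 of the 3 values shown sit.

Compound 4 `COc1cccc(Br)c1-c1nc(CN2CCC(C(=O)NCCCN3C[C@H](C)C[C@H](C)C3)CC2)c(C)o1` has not been measured. It carries 2-bromo-6-methoxyphenyl in place of 2,6-dichlorophenyl, and the rest of the molecule stays the same: 2-bromo-6-methoxyphenyl in place of 2,6-dichlorophenyl on an aromatic carbon.

Within the data shown here, only one measured step bears on this change. It is large: an at least 10-fold lower number from compound 1 to compound 3 (1.01 log units; beyond the scatter). That step brought in 2,6-dichlorophenyl in place of 4-chlorophenyl, and the new group in compound 4 also has substituents numbered 2 and 6. Among the measured compounds shown here, no measured step covers the bromine or the methoxy group, so this is a cautious reading. The expectation therefore stays close to compound 3 and its 0.0483 h, with a short half-life in this assay. The expected change is a 1.0-fold higher number from compound 3 to compound 4 (0.02 log units; within the scatter), with no step beyond the usual scatter in either direction. For compound 4 the estimated half-life is 0.05 h, with an expected range of 0.02 h to 0.15 h.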

Compound 4, half-life: 0.0583 h
The estimate for compound 4 lay 1.2-fold (0.07 log units) below the measured number; the range from low to high includes it.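

With 2-bromo-6-methoxyphenyl in place of 2,6-dichlorophenyl, this assay shows a 1.2-fold higher number from compound 3 to compound 4 (0.08 log units; within the scatter), so at this position the short half-life does not depend on having two chlorines. Against 4-chlorophenyl, the same new group gives an at least 8.5-fold lower number from compound 1 to compound 4 (0.93 log units; beyond the scatter), so a second group with substituents numbered 2 and 6 stands well apart from the 4-chlorophenyl compound. That step is only a minimum, because compound 1 gives a limit of the assay and not a number: the limit of > 0.5 h in this assay, at which 2 of the 4 values shown sit.

The compounds shown leave open whether one substituent alone, as in 2-methoxyphenyl or 2-bromophenyl, would give the same short half-life. They also leave open how smaller atoms such as two fluorines would fare on this ring.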